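From a methyl-bearing ring to a chlorinated one

This account rests on a few compounds, and the source may have more. Where it says the series, first, only, none or still open, it means among the compounds named here.

The three measured compounds were all tested in an assay on isolated protein for inhibition of Amine oxidase [flavin-containing] B (Homo sapiens), read by fluorescence and Amplex Red, with stated times of 15 min and 20 min; a higher number here means a weaker inhibitor, a lower number a stronger inhibitor:
compound 1, `Oc1cccc(/C=N/c2ccc(OCc3ccccc3)cc2)c1O`, gives 6870 nM;
compound 2, `Cc1ccc(/C=N/c2ccc(OCc3ccccc3)cc2)c(O)c1`, gives 24400 nM;
compound 3, `Oc1ccc(Br)cc1/C=N/c1ccc(OCc2ccccc2)cc1`, gives 31700 nM.

Compound 2 holds the second highest number of the three in this assay. Its nearest neighbour is compound 3, with a step of a 1.3-fold higher number from compound 2 to compound 3 (0.11 log units; within the scatter), so the two cannot be told apart on these numbers; compound 1 sits further off, with a 3.6-fold higher number from compound 1 to compound 2 (0.55 log units; beyond the scatter).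

Compound 4, `Oc1ccc(Cl)cc1/C=N/c1ccc(OCc2ccccc2)cc1`, is the next compound to be examined. It differs from compound 2 in one place: 5-chloro-2-hydroxyphenyl in place of 2-hydroxy-4-methylphenyl on a carbon with a double bond to nitrogen. The measured steps that bear on this are a 1.3-fold higher number from compound 2 to compound 3 (0.11 log units; within the scatter) and a 4.6-fold higher number from compound 1 to compound 3 (0.66 log units; beyond the scatter). Compound 3 carries a bromine where compound 4 carries a chlorine, so compound 3 is the closest reference point. The change from compound 2 to compound 3 stayed within the scatter, and both of these compounds gave clearly higher numbers than compound 1. A step from compound 2 to compound 4 of a 1.1-fold higher number from compound 2 to compound 4 (0.04 log units; within the scatter) is therefore expected, which amounts to no change beyond the scatter. Compound 4 is estimated at 27000 nM in this assay, within a range from 12000 nM to 60000 nM.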

Compound 4, half-maximal inhibitory concentration: 24800 nM
The estimate for compound 4 lay 1.1-fold (0.04 log units) above the measured number, and the stated range covers the measured number.
By their numbers in this assay, from the lowest: compound 1; then compounds 2, 4 and 3 (each within the scatter of the next).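

Chlorine gives the first direct halogen comparison on this ring: chloro in place of bromo on an aromatic carbon leaves the result within the scatter (a 1.3-fold lower number from compound 3 to compound 4 (0.11 log units; within the scatter)). The chlorinated ring also cannot be told apart from the methyl-bearing ring in this assay (a 1.0-fold higher number from compound 2 to compound 4 (0.01 log units; within the scatter)), so these three substituted rings form one group on these numbers, even though the swap from compound 2 to compound 4 replaces a carbon-based group with a halogen and changes where it sits in the name of the ring. Compound 1 remains the only one set apart, now also against the chlorinated ring, and that gap lies beyond the scatter (a 3.6-fold higher number from compound 1 to compound 4 (0.56 log units; beyond the scatter)), while nothing available here accounts for either the sameness of the three or the gap.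

The compounds shown leave open how a fluoro, a methoxy or an amine would compare on this ring. They also cannot say whether the gap to the 2,3-dihydroxyphenyl ring would persist if the rest of the shared core carried a longer chain or a carboxylic acid.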